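This account rests on a few compounds, and the source may have more. Where it says the series, first, only, none or still open, it means among the compounds named here.

Compound 1 `C[C@@H]1O[C@H](N2C(=O)/C(=C3\Nc4ccccc4C3=O)c3ccccc32)[C@H](O)[C@H](O)[C@H]1O`: > 12500 nM
Compound 2 `O=C1/C(=C2/C(=O)N([C@@H]3O[C@H](CO)[C@H](O)[C@H](O)[C@H]3O)c3ccccc32)Nc2ccccc21`: 13200 nM
Compound 3 `C[C@@H]1O[C@H](N2C(=O)/C(=C3\Nc4ccccc4\C3=N/O)c3ccccc32)[C@H](O)[C@H](O)[C@H]1O`: "not determined" (no result reported)

For the measured compounds named here, in a functional assay on A-427 cells (Homo sapiens) for antiproliferative activity, read by crystal violet staining, with a stated time of 96 h (on this read-out lower numbers stand for stronger inhibition and higher numbers for weaker inhibition), compound 2 gives 13200 nM, the only plain number among the three. In this assay compound 1 gives > 12500 nM, which is a limit of the assay, not a number, and it sits at the limit of > 12500 nM in this assay, at which 1 of the 3 values shown sits. In this assay compound 3 gives "not determined" (no result reported), so no result is reported for it. Compound 4 `O=C1/C(=C2/C(=O)N([C@@H]3O[C@H](CO)[C@@H](O)[C@H](O)[C@H]3O)c3ccccc32)Nc2ccccc21` is not yet measured; it differs from compound 2 in this way: the two compounds have the same atoms and bonds and differ only in configuration as drawn: 1 of 6 stereo elements differ; a stereocentre at a saturated ring carbon is drawn R in compound 2 and S in compound 4. Going by the values given here, no step between two measured compounds is available, so no direction for this change can be drawn from the data. The expected step of a 1.0-fold lower number from compound 2 to compound 4 (0.01 log units; within the scatter) is within the usual scatter. Compound 4 is therefore expected to give about 13000 nM, between 5000 nM and 40000 nM.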

Compound 4, half-maximal inhibitory concentration: 11800 nM
Beside the measured number, compound 4's estimate is 1.1-fold (0.04 log units) above it; the measured number falls inside the stated range.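

Reversing this one stereocentre at a saturated ring carbon from R to S gives the first readable comparison in this assay: there is a 1.1-fold lower number from compound 2 to compound 4 (0.05 log units; within the scatter). At this position, the drawn configuration therefore makes no difference that can be told from the usual scatter of the assay. The comparison isolates this single change, and nothing else can contribute to it: the fact that compounds 2 and 4 differ only in the configuration as drawn

As far as these compounds go, whether a different group at this carbon, such as an amine in place of the hydroxyl, would move the number stays open. So does the effect of reversing the other stereocentres.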